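Replacing Cyclohexyl on the Amide Nitrogen of Compound 3

The source may report more compounds than this note shows. Statements on the series, on what has been measured and on what is new or still open speak of the compounds shown alone.

Compound 1, `COCCNC(=O)c1cc2cccc(OC)c2oc1=N`, gives 43% in an assay on HEK293 cells for displacement of a labelled ligand from adenosine receptor A2b (Homo sapiens), read by scintillation counting, with a stated time of 30 min, tested at 10 uM; on this read-out lower numbers stand for less inhibition and higher numbers for more inhibition at the one concentration tested (going by the name of the read-out).
Compound 2, `CCC(CO)NC(=O)c1cc2cccc(OC)c2oc1=N`, gives 39% in this assay.
Compound 3, `COc1cccc2cc(C(=O)NC3CCCCC3)c(=N)oc12`, gives > 70% in this assay, which is a limit of the assay and not a number (the limit of > 70% in this assay, at which 1 of the 3 values shown sits).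

All three share one core and differ only in the group on the amide-type nitrogen. Compound 3 stands apart: the change a number at least 27 percentage points higher from compound 1 to compound 3 (beyond the scatter) and the change a number at least 31 percentage points higher from compound 2 to compound 3 (beyond the scatter) both go up beyond the scatter, while a number 4 percentage points lower from compound 1 to compound 2 (within the scatter) stays within it.

Compound 4, `COc1cccc2cc(C(=O)NC(CO)(CO)CO)c(=N)oc12`, is not yet measured. It differs from compound 3 by 2-hydroxy-1,1-bis(hydroxymethyl)ethyl in place of cyclohexyl on an amide-type nitrogen. This undoes the entry of cyclohexyl that marked the two rising steps, so the step from compound 3 to compound 4 is expected to run the other way, with a drop at least as large as those rises, giving a number at least 45 percentage points lower from compound 3 to compound 4 (beyond the scatter). Compound 4 is therefore estimated at 25% in this assay, between 5% and 50%.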

Compound 4, a percentage reported as inhibition, at one concentration (the size of the read-out at that concentration, not a potency): 28%
Estimate against measurement, compound 4: 3 percentage points below; low and high end bracket the measured number.
By their numbers in this assay, from the lowest: compound 4; then compounds 2 and 1 (each within the scatter of the next). At a limit, above all of these: compound 3.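

With 2-hydroxy-1,1-bis(hydroxymethyl)ethyl on the amide-type nitrogen, the loss of cyclohexyl shows up as a number at least 42 percentage points lower from compound 3 to compound 4 (beyond the scatter). Compound 3 stands at a limit and not a number: the limit of > 70% in this assay, at which 1 of the 4 values shown sits. Before this result, the two groups without a ring could not be told apart in this assay, but this third group without a ring can be separated from both, giving a number 11 percentage points lower from compound 2 to compound 4 (beyond the scatter) and a number 15 percentage points lower from compound 1 to compound 4 (beyond the scatter), so the groups without a ring do not all read alike at this position.

This change removes the ring and brings in the hydroxyl groups in one step, so the compounds shown cannot tell which of the two matters more. Going by these compounds, a cyclohexyl ring carrying a single hydroxyl, a phenyl ring, or a longer carbon chain with no oxygen on the same nitrogen remains open.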